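Replacing a Pyrazolyl Group with Dimethylamino on the Shared Core

A few compounds are considered here, and "the series" means these few. Any claim that something is new, unique, unknown or untested is made for them only; others in the source may bear on it.

Measured compounds:
compound 1 `COc1cc(-c2cnn3cc(OC)c(-c4cnn(C)c4)nc23)ccn1`: 56%
compound 2 `COc1cc(-c2cnn3cc(OC)c(-c4cc(C)no4)nc23)ccn1`: 62%
compound 3 `COc1cc(-c2cnn3cc(OC)c(C(C)(C)O)nc23)ccn1`: 92%

In an ADME assay on microsomes from liver (Rattus norvegicus) for metabolic stability, with a stated time of 60 min, tested at 1 uM (on this read-out lower numbers stand for a less stable compound and higher numbers for a more stable compound), compound 1 gives 56%, the lowest of the three numbers. Compound 2 lies close by, a number 6 percentage points higher from compound 1 to compound 2 (within the scatter). Compound 3 stands far apart, a number 36 percentage points higher from compound 1 to compound 3 (beyond the scatter), and likewise a number 30 percentage points higher from compound 2 to compound 3 (beyond the scatter).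

Compound 4 `COc1cc(-c2cnn3cc(OC)c(N(C)C)nc23)ccn1` carries dimethylamino in place of 1-methyl-1H-pyrazol-4-yl on an aromatic carbon. Neither measured step matches this change: the step from compound 1 to compound 2 swaps one five-membered aromatic ring for another, and the steps to compound 3 introduce a hydroxyl-bearing group, which dimethylamino lacks. The data therefore give no direct guide, and no step beyond the scatter is expected; the estimate is a number 1 percentage points lower from compound 1 to compound 4 (within the scatter). Compound 4 is expected at 55%, within 30% to 80%.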

Compound 4, percent of the compound remaining: 3%
Estimate against measurement, compound 4: 52 percentage points above; measured number below the stated range.
By their numbers in this assay, from the lowest: compound 4; then compounds 1 and 2 (each within the scatter of the next); then compound 3.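

In this assay the change to dimethylamino on this aromatic carbon gives a number 53 percentage points lower from compound 1 to compound 4 (beyond the scatter) and a number 59 percentage points lower from compound 2 to compound 4 (beyond the scatter) and also a number 89 percentage points lower from compound 3 to compound 4 (beyond the scatter) on the shared core. The earlier steps shown here at this position showed only a change within the scatter or a rise, so a large fall here is new, and it comes with a group that has no ring. Nothing measured here accounts for this fall. As far as these compounds go, whether another amine at this position, such as pyrrolidine or morpholine, would behave like dimethylamino stays open, as does the effect of longer chains on the nitrogen, such as diethylamino.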